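Amide nitrogen swap from compound 1 to compound 4

A few compounds are considered here, and "the series" means these few. Any claim that something is new, unique, unknown or untested is made for them only; others in the source may bear on it.

Measured so far in a functional assay on MGC-803 cells (Homo sapiens) for inhibition, read by MTT assay, with a stated time of 72 h; a higher number here means a weaker inhibitor, a lower number a stronger inhibitor
- compound 1 (`COc1ccc(NC(=O)C2CCN(C/C=C/c3ccccc3)CC2)cc1`) gives 58200 nM
- compound 2 (`CN1CCN(c2ccc(NC(=O)C3CCN(C/C=C/c4ccccc4)CC3)cc2)CC1`) gives 14000 nM
- compound 3 (`O=C(Nc1cccc2cccnc12)C1CCN(C/C=C/c2ccccc2)CC1`) gives 38200 nM

Compound 1 (58200 nM) and compound 3 (38200 nM) lie within the scatter of each other, at the high-number end of this small set. Compound 2 (14000 nM) lies clear of compound 1 on the lower side.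

Next is compound 4 (`O=C(Nc1ccccn1)C1CCN(C/C=C/c2ccccc2)CC1`), with pyridin-2-yl in place of 4-methoxyphenyl on an amide-type nitrogen. Going by the values given here, the only measured step (a 4.2-fold lower number from compound 1 to compound 2 (0.62 log units; beyond the scatter)) is modest and comes from a change on an aromatic carbon, so it bears on this swap only loosely. Closer evidence is compound 3 (38200 nM), which carries a different group on the amide-type nitrogen and stays within the scatter of compound 1. No shift beyond the scatter is therefore expected in this assay, and any small move would more likely be towards a lower number. The expected step is small (a 1.5-fold lower number from compound 1 to compound 4 (0.16 log units; within the scatter)). Expected for compound 4 is 40000 nM (estimated range 16000 nM to 90000 nM).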

Compound 4, half-maximal inhibitory concentration: 45200 nM
The estimate for compound 4 lay 1.1-fold (0.05 log units) below the measured number; the range from low to high includes it.
By their numbers in this assay, from the lowest: compound 2; then compounds 3, 4 and 1 (each within the scatter of the next).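

On the amide-type nitrogen, pyridin-2-yl stands in for 4-methoxyphenyl without a shift beyond the scatter in this assay (a 1.3-fold lower number from compound 1 to compound 4 (0.11 log units; within the scatter)). Going by these compounds alone, the exchange replaces a carbon-only aromatic ring with a smaller group whose aromatic ring holds one hetero atom, and this is the first reading at this position for a single six-membered ring other than the one in compound 1. Together with compound 3, which also stays within the scatter of compound 1, the three aromatic groups on this nitrogen give no clear separation, and no measurement at hand accounts for this.

Open, on these data alone, is whether a saturated cyclohexyl or a benzyl group on the same nitrogen would keep the number in this range. Also open, as far as these compounds go, is whether 4-methylpiperazin-1-yl on the pyridin-2-yl ring of compound 4 would repeat the step seen on the other ring (a 4.2-fold lower number from compound 1 to compound 2 (0.62 log units; beyond the scatter)).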